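Swapping the naphthyl ketone for a fluorophenyl ketone

This account rests on a few compounds, and the source may have more. Where it says the series, first, only, none or still open, it means among the compounds named here.

Compound 1 `CC1(C)S[C@@H]2/C(=C\C(=O)c3ccc4ccccc4c3)C(=O)N2[C@H]1C(=O)OC(c1ccccc1)c1ccccc1` is the reference point of this small series. In a functional assay on A-375 cells (Homo sapiens) for cytotoxicity, read by MTT assay, with a stated time of 48 h (a lower number here means a stronger inhibitor, a higher number a weaker inhibitor), compound 1 gives 36500 nM, the lowest of the two numbers reported. Compound 3 `CC1(C)[C@H](C(=O)OC(c2ccccc2)c2ccccc2)N2C(=O)/C(=C/C(=O)c3ccc([N+](=O)[O-])cc3)[C@H]2S1(=O)=O` gives 76700 nM in this assay, a gap beyond the scatter of this kind of measurement. Among the compounds with values here, compound 2 `CC1(C)S[C@@H]2C/C(=C\C(=O)c3ccccc3)C(=O)N2[C@H]1C(=O)OC(c1ccccc1)c1ccccc1` is reported only as a limit of this assay, > 100000 nM, and it is the one value of the three that sits at that limit (the limit of > 100000 nM in this assay, at which 1 of the 3 values shown sits).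

Compound 4 `CC1(C)S[C@@H]2/C(=C\C(=O)c3ccc(F)cc3)C(=O)N2[C@H]1C(=O)OC(c1ccccc1)c1ccccc1` has not been measured. Its structure differs from compound 1 in one place: 4-fluorophenyl in place of naphthalen-2-yl on a carbonyl carbon. The smaller aryl ketone of compound 4 is closer in spirit to the phenyl ketone of compound 2, whose result is a limit rather than a number.

The account therefore expects compound 4 to lose potency against compound 1, a step estimated at a 1.9-fold higher number from compound 1 to compound 4 (0.28 log units; within the scatter) in this assay. For compound 4 the estimate in this assay is 70000 nM, with a range from 30000 nM to 160000 nM.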

Compound 4, half-maximal inhibitory concentration: 17800 nM
For compound 4 the middle estimate is 3.9-fold (0.59 log units) above the measured one, outside the stated range (below it).
By their numbers in this assay, from the lowest: compound 4; then compound 1; then compound 3. At a limit, above all of these: compound 2.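

Within the data shown here, the change to 4-fluorophenyl in place of naphthalen-2-yl on a carbonyl carbon gives, in this assay, a 2.1-fold lower number from compound 1 to compound 4 (0.31 log units; beyond the scatter), the first step that can be read for one change alone. It shows that at this position the second aromatic ring of naphthalen-2-yl is not required for the activity seen here: the smaller aryl ketone retains that activity, and the number moves modestly in the favourable direction. Nothing shown gives a measured property that would account for this step.

The compounds shown do not separate the contribution of the fluorine from that of removing the second ring. They also leave open how a 4-methoxyphenyl, a 4-aminophenyl or a pyridine ring would read on this carbonyl carbon.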